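The source may hold more compounds than are shown below. What is called first, only, known or untested is meant among the compounds shown, and "the series" means these compounds.

Within the data shown here, compound 1 `COc1ccc(-n2c(SCc3ccc(C)cc3)nnc2-c2cc(OC)c(OC)c(OC)c2)cc1` is the only member of this small set that gives a number in a functional assay on HepG2 cells (Homo sapiens) for inhibition, read by MTT assay, with a stated time of 48 h; on this read-out higher numbers stand for weaker inhibition and lower numbers for stronger inhibition: compound 1 gives 31600 nM. Compound 2 `COc1ccc(-n2c(SCC(=O)c3ccc(OC)c(O)c3)nnc2-c2cc(OC)c(OC)c(OC)c2)cc1` reaches only a limit of the assay in this assay, where compound 2 gives > 60000 nM. Compound 3 `COc1ccc(-n2c(SCC(=O)c3ccc4ccccc4c3)nnc2-c2cc(OC)c(OC)c(OC)c2)cc1` likewise stops at a limit in this assay, as compound 3 gives > 60000 nM. Compounds 2 and 3 thus share (the limit of > 60000 nM in this assay, at which 2 of the 3 values shown sit). Compound 4 `COc1ccc(NC(=O)CSc2nnc(-c3cc(OC)c(OC)c(OC)c3)n2-c2ccc(OC)cc2)cc1` has not yet been measured; it differs from compound 1 as follows: (4-methoxyphenyl)carbamoyl in place of 4-methylphenyl on a saturated chain carbon bound to a sulfur. Among the measured compounds shown here, two measured steps bear on this change, and both replace the same 4-methylphenyl with a group carrying a carbonyl on the saturated chain carbon bound to a sulfur: an at least 1.8-fold higher number from compound 1 to compound 2 (0.27 log units; that floor lies within the scatter) and an at least 1.8-fold higher number from compound 1 to compound 3 (0.27 log units; that floor lies within the scatter). The step between the two limits, a step that the two limits leave unreadable from compound 2 to compound 3, adds nothing readable. Both usable steps point the same way, toward a higher number whose floor is within the scatter. Compound 4 is expected to follow them, with a 1.9-fold higher number from compound 1 to compound 4 (0.28 log units; within the scatter). Compound 4 is accordingly estimated at 60000 nM, within 25000 nM to 150000 nM, and quite possibly reported only as a limit.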

Compound 4, half-maximal inhibitory concentration: > 60000 nM
Compound 4: no number, only a limit; the forecaster's own chance of this, stated with the estimate: 60%; the middle value sits exactly at the limit.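

The limit of the assay reached by compound 4 gives only a floor, an at least 1.8-fold higher number from compound 1 to compound 4 (0.27 log units; that floor lies within the scatter), so the (4-methoxyphenyl)carbamoyl group, with its amide hydrogen, yields no number in this assay. This is the third group with a carbonyl on the saturated chain carbon bound to a sulfur to stop at the same limit, and a carbamoyl group now stands there alongside the aryl carbonyl groups of compound 2 and compound 3: the limit of > 60000 nM in this assay, at which 3 of the 4 values shown sit. The steps from compound 2 and from compound 3 to compound 4 join two limits and cannot be read, so no order among these three can be given.

On these data alone, it remains open whether a 4-methoxybenzyl group, which has no carbonyl, would give a number at this place. The same holds for a carboxylic acid or a longer chain on that carbon.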